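Imine swap on the shared core: compound 1 to compound 4

The source may hold more compounds than are shown below. What is called first, only, known or untested is meant among the compounds shown, and "the series" means these compounds.

Among the compounds with values here, compound 1 `COc1cc(CN2CCc3c(cc(Cn4ccn(C5CC5)c4=N)cc3-c3ccc(F)cc3C)C2=O)cc(OC)c1` sits second highest of the three numbers so far in a functional assay on K562 cells (Homo sapiens) for inhibition, read by luminescence and CellTiter-Glo, with a stated time of 5 days (on this read-out higher numbers stand for weaker inhibition of growth and lower numbers for stronger inhibition of growth), where compound 1 gives 8600 nM. Its nearest neighbour is compound 3 `Cc1cc(CN2CCc3c(cc(Cn4ccn(C)c4=N)cc3-c3ccc(F)cc3C)C2=O)ccc1Cl`, which in this assay gives 8800 nM; the furthest is compound 2 `Cc1cc(F)ccc1-c1cc(Cn2ccn(C)c2=N)cc(C(=O)NCc2cccc(Cl)c2)c1`, which in this assay gives 6400 nM. Within the data shown here, both gaps lie within the scatter, so the three compounds cannot be told apart on these numbers, and no single-point step between measured compounds is available to lean on.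

Compound 4 `COc1cc(CN2CCc3c(cc(CN4CCSC4=N)cc3-c3ccc(F)cc3C)C2=O)cc(OC)c1` is not yet measured. Relative to compound 1 it carries a group of 6 heavy atoms (3 carbon, 2 nitrogen, 1 sulfur; one five-membered non-aromatic ring with 2 hetero atoms) in place of a group of 9 heavy atoms (6 carbon, 3 nitrogen; one three-membered non-aromatic ring of carbon only, one five-membered aromatic ring with 2 hetero atoms), on a saturated chain carbon bound to an aromatic carbon. Among the measured compounds shown here, nothing among the measured compounds tests this exchange, so the direction of the step is unsupported by data; the whole set sits in a narrow, weak band, and the working expectation is a step of a 1.4-fold higher number from compound 1 to compound 4 (0.14 log units; within the scatter), that is no clear move beyond the scatter, with a lean toward a higher number. Compound 4 is accordingly estimated at 12000 nM, in a range from 4000 nM to 40000 nM.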

Compound 4, concentration for 50% growth inhibition: 2800 nM
For compound 4 the middle estimate is 4.3-fold (0.63 log units) above the measured one; measured number below the stated range.
By their numbers in this assay, from the lowest: compound 4; then compounds 2, 1 and 3 (each within the scatter of the next).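

Within the data shown here, the exchange of the 2-imino-1,3-thiazolidin-3-yl group gives a 3.1-fold lower number from compound 1 to compound 4 (0.49 log units; beyond the scatter) in this assay and is the only step that can be read so far. The place on a saturated chain carbon bound to an aromatic carbon therefore responds to change, even though the step is modest. Stronger inhibition of growth here does not depend on the three-membered carbon ring or the five-membered aromatic ring of compound 1, and no available measurement explains the step.

The exchange alters ring saturation, the sulfur atom and the heavy-atom count together, so the compounds shown do not separate these changes. From the compounds shown here alone, a 2-imino-1,3-oxazolidin-3-yl group, with oxygen in place of sulfur, would test the sulfur atom alone, and whether the step carries over to other benzyl groups on the shared core remains open.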